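This account rests on a few compounds, and the source may have more. Where it says the series, first, only, none or still open, it means among the compounds named here.

Compound 2 `CC(C)N(C(=S)SCc1oc2ccccc2c(=O)c1Cl)C(C)C` gives the highest number of the two measured here in a functional assay on MDA-MB-435S cells (Homo sapiens) for antiproliferative activity, read by MTT assay, with a stated time of 72 h (on this read-out lower numbers stand for stronger inhibition and higher numbers for weaker inhibition), with 23600 nM; the nearest measured compound, compound 1 `COc1ccc2occ(CSC(=S)N(C(C)C)C(C)C)c(=O)c2c1`, gives a markedly lower number, 1800 nM. Compound 3 `O=c1c(Cl)c(CSC(=S)N2CCOCC2)oc2ccccc12` is reached from compound 2 by a single change, (morpholin-4-yl in place of diisopropylamino on a thiocarbonyl carbon). No step of this kind has been measured among the compounds shown, so the expectation is a step of no size beyond the scatter in either direction, a 1.2-fold lower number from compound 2 to compound 3 (0.07 log units; within the scatter). On that basis compound 3 is estimated at 20000 nM in this assay, within a range from 5000 nM to 80000 nM.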

Compound 3, half-maximal inhibitory concentration: 4100 nM
Compound 3: middle estimate off by 4.9-fold (0.69 log units), on the high side; measured number outside the range, below it.
By their numbers in this assay, from the lowest: compound 1; then compound 3; then compound 2.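

Morpholin-4-yl in place of diisopropylamino on a thiocarbonyl carbon brings a 5.8-fold lower number from compound 2 to compound 3 (0.76 log units; beyond the scatter) in this assay and so gives the first step read at this position. It shows that the number in this assay responds to the amine group on the thiocarbonyl carbon while the rest of compound 2 stays unchanged. Nothing available accounts for the size or direction of this step.

On these data alone, whether piperidine or piperazine in this place would give a similar number remains open. So does whether morpholin-4-yl would bring a step of this kind on the core of compound 1.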